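This account rests on a few compounds, and the source may have more. Where it says the series, first, only, none or still open, it means among the compounds named here.

Measured so far:
compound 1 `Cc1ccoc1-c1ccccc1OCC1=NCCN1` — 99%
compound 2 `Cc1ccc(-c2ccccc2OCC2=NCCN2)s1` — 97%

Of the two numbers, compound 2 gives the numerically lower one, but the gap to compound 1 is within the scatter, so the two are not distinguished. In a functional assay with Alpha-1A adrenergic receptor (Homo sapiens) as the target, read by calcium flux (a lower number here means a smaller maximal response, a higher number a larger maximal response), compound 2 gives 97%. Compound 3 `Cc1csc(-c2ccccc2OCC2=NCCN2)n1` differs from compound 2 by 4-methyl-1,3-thiazol-2-yl in place of 5-methylthiophen-2-yl on an aromatic carbon. Going by the values given here, the only measured step, a number 2 percentage points lower from compound 1 to compound 2 (within the scatter), replaced one five-membered aromatic ring with another and left the maximal response unchanged; the ring entering compound 3 itself has no measurement. No step beyond the scatter is therefore expected, with a number 2 percentage points lower from compound 2 to compound 3 (within the scatter) as the expected step. Compound 3 is estimated at 95%, range 80% to 105%.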

Compound 3, largest response reached (reported as maximum), in percent of the reference or control that the assay uses: 104%
Compound 3: the middle estimate sits 9 percentage points below what was measured; measured number inside the range.
By their numbers in this assay, from the lowest: compounds 2, 1 and 3 (each within the scatter of the next).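

Placing 4-methyl-1,3-thiazol-2-yl on this aromatic carbon brings a second ring hetero atom and a second hydrogen-bond acceptor, yet in this assay neither step leaves the scatter (a number 7 percentage points higher from compound 2 to compound 3 (within the scatter); a number 5 percentage points higher from compound 1 to compound 3 (within the scatter)). The three five-membered aromatic rings at this place are therefore not distinguished by maximal response, now including a ring with 2 hetero atoms. No supporting evidence bears on this result.

Still open, on these data alone, is whether an amine, a carboxylic acid or a plain phenyl ring at this place would shift the maximal response. Also open, as far as these compounds go, is what an unmethylated thiazol-2-yl ring would give.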